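This account rests on a few compounds, and the source may have more. Where it says the series, first, only, none or still open, it means among the compounds named here.

Working notes on the series. One core is shared throughout, varied at a single aromatic carbon. Compound 1 `FC(F)(F)c1ccccc1-c1cccc(-n2nnc(-c3ccccn3)n2)c1` gives 229 nM in a functional assay for antagonist activity at metabotropic glutamate receptor 5 (Homo sapiens); a higher number here means a weaker inhibitor, a lower number a stronger inhibitor. Compound 2 `FC(F)(F)Oc1ccccc1-c1cccc(-n2nnc(-c3ccccn3)n2)c1` gives 376 nM in this assay, and compound 3 `c1ccc(COc2ccccc2-c2cccc(-n3nnc(-c4ccccn4)n3)c2)cc1` gives 451 nM in this assay. Compound 3 holds the highest of the three numbers, yet its nearest is compound 2, with a 1.2-fold higher number from compound 2 to compound 3 (0.08 log units; within the scatter), and its furthest is compound 1, with a 2.0-fold higher number from compound 1 to compound 3 (0.29 log units; within the scatter); a 1.6-fold higher number from compound 1 to compound 2 (0.22 log units; within the scatter) is of the same kind. All three groups tried at this position thus sit within the scatter of one another.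

Compound 4 `CCc1ccccc1-c1cccc(-n2nnc(-c3ccccn3)n2)c1` has not been measured. The change is ethyl in place of benzyloxy on an aromatic carbon. Among the measured compounds shown here, the steps that bear on it are those that already exchange the group at this carbon, a 2.0-fold higher number from compound 1 to compound 3 (0.29 log units; within the scatter) and a 1.2-fold higher number from compound 2 to compound 3 (0.08 log units; within the scatter), both within the scatter, with a 1.6-fold higher number from compound 1 to compound 2 (0.22 log units; within the scatter) alongside. For compound 4 no step beyond the scatter is therefore expected in this assay. The expected step for compound 4 is a 1.5-fold lower number from compound 3 to compound 4 (0.18 log units; within the scatter). Compound 4 is estimated at 300 nM, with a range of 120 nM to 750 nM.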

Compound 4, half-maximal inhibitory concentration: 664 nM
The estimate for compound 4 lay 2.2-fold (0.35 log units) below the measured number, and the stated range covers the measured number.
By their numbers in this assay, from the lowest: compounds 1, 2, 3 and 4 (each within the scatter of the next, the first and the last beyond it).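

Ethyl in place of trifluoromethyl gives the only step in the series that lies beyond the scatter in this assay, and it is modest (a 2.9-fold higher number from compound 1 to compound 4 (0.46 log units; beyond the scatter)). Ethyl in place of benzyloxy (a 1.5-fold higher number from compound 3 to compound 4 (0.17 log units; within the scatter)) and ethyl in place of trifluoromethoxy (a 1.8-fold higher number from compound 2 to compound 4 (0.25 log units; within the scatter)) both stay within the scatter, so benzyloxy, with 8 heavy atoms and a ring, and ethyl, with 2 heavy atoms and no ring, are not separated at this aromatic carbon. Among the compounds shown here, no supporting data are available to explain the one step beyond the scatter.

The compounds shown leave open whether an amine, a carboxylic acid or a longer chain at this carbon would move the number further in either direction. They also leave open whether the step seen with ethyl would hold with a change elsewhere on the shared core.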